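Azide to primary amine: metabolic stability notes

The compounds below may be only part of what the source reports. "The series", "measured", "known", "first", "only" and "open" are said of these compounds alone.

Measured so far in an ADME assay on microsomes from liver (Homo sapiens) for metabolic stability, read by LC-MS, using NADPH, tested at 5 uM; a lower number here means that the compound disappears faster, a higher number that the compound lasts longer:
- compound 1 `NS(=O)(=O)c1cc(-c2nnc(CN3CCN(c4ccc(F)cc4)CC3)o2)c(Cl)cc1SCc1ccccc1` — 0.527 h
- compound 2 `Cc1ccc(C)c(N2CCN(Cc3nnc(-c4cc(S(N)(=O)=O)c(SCc5ccccc5)cc4Cl)o3)CC2)c1` — 0.208 h
- compound 3 `[N-]=[N+]=NCc1nnc(-c2cc(S(N)(=O)=O)c(SCc3ccccc3)cc2Cl)o1` — > 1 h

Going by the values given here, only one pair of measured compounds differs in a single place, and that step is a 2.5-fold lower number from compound 1 to compound 2 (0.40 log units; beyond the scatter). It alters the aryl group on the amine nitrogen in a ring and does not touch the part of the molecule at issue below.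

Compound 3 stands apart. In this assay compound 3 gives > 1 h, which is a limit of the assay and not a number; compound 3 sits at the limit of > 1 h in this assay, at which 1 of the 3 values shown sits. Where compound 3 lies in relation to the other two values cannot be stated in numbers.

The next compound, compound 4 `NCc1nnc(-c2cc(S(N)(=O)=O)c(SCc3ccccc3)cc2Cl)o1`, differs from compound 3 by amino in place of azido on a saturated chain carbon bound to an aromatic carbon. Among the compounds with values here, no measured step bears on this change; the one step available concerns a different group, so it gives no size to borrow. With compound 3 already at the limit, the step to compound 4 is expected to be a step that the limit leaves unreadable from compound 3 to compound 4, that is, nothing clearly beyond the scatter in either direction. Compound 4 is therefore expected to give about 1.2 h, within a range from 0.5 h to 3 h, with a fair chance that this assay again reports only a limit.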

Compound 4, half-life: 0.263 h
Beside the measured number, compound 4's estimate is 4.6-fold (0.66 log units) above it; the measured number lies below the stated range.
By their numbers in this assay, from the lowest: compounds 2, 4 and 1 (each within the scatter of the next, the first and the last beyond it). At a limit, above all of these: compound 3.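

Replacing azido with amino on a saturated chain carbon bound to an aromatic carbon gives, in this assay, an at least 3.8-fold lower number from compound 3 to compound 4 (0.58 log units; beyond the scatter), so the half-life responds to the group at this position, which the earlier step, made elsewhere in the molecule, could not show. Going by these compounds alone, compound 4 gives 0.263 h, a measured number rather than a limit, and so provides the first readable value for a compound with a small group at this position. The value for compound 3 is a limit of the assay and not a number, so the printed step sets only a lower bound on the size of the change and its full size remains unknown: the limit of > 1 h in this assay, at which 1 of the 4 values shown sits.

On these data alone, it remains open whether the lower number belongs specifically to the primary amine or would recur with other groups on this carbon, such as a hydroxyl, a methylamino group or an acetamide. As far as these compounds go, it is also open how a longer chain between the amino group and the shared core would read in this assay.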